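The compounds below may be only part of what the source reports. "The series", "measured", "known", "first", "only" and "open" are said of these compounds alone.

Working notes on the aryl glucoside series.

Compound 2 `Cc1cccc(-c2ccc(O[C@H]3O[C@H](CO)[C@@H](O)[C@H](O)[C@@H]3O)c(Cl)c2)c1` is the reference point here. In a physicochemical assay for lipophilicity, read by LC-MS, measured as octanol-water partition, with a stated time of 2 h, at pH 7.4, tested at 1 uM (a higher number here means a more lipophilic compound, a lower number a more polar compound), compound 2 gives 3, the highest of the two numbers available. Among the compounds with values here, the nearest comparison is compound 1 `O=[N+]([O-])c1ccc(-c2ccc(O[C@H]3O[C@H](CO)[C@@H](O)[C@H](O)[C@@H]3O)c(Cl)c2)cc1`, which in this assay gives 2.3; the single measured step, a number 0.70 log units higher from compound 1 to compound 2 (beyond the scatter), came from replacing 4-nitrophenyl with 3-methylphenyl. Compound 3 `OC[C@H]1O[C@H](Oc2ccc(-c3ccc(Cl)c(C(F)(F)F)c3)cc2Cl)[C@@H](O)[C@@H](O)[C@@H]1O` in this assay stands at "not determined" (no result reported), so it offers no number to compare.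

The next compound, compound 4 `O=[N+]([O-])c1cccc(-c2ccc(O[C@H]3O[C@H](CO)[C@@H](O)[C@H](O)[C@@H]3O)c(Cl)c2)c1`, differs from compound 2 in one place: nitro in place of methyl on an aromatic carbon. The nitro sits on an aromatic carbon of a six-membered aromatic ring of carbon only, meta to a large group; taken one bond further out the change reads 3-methylphenyl to 3-nitrophenyl.

Within the data shown here, only the step of a number 0.70 log units higher from compound 1 to compound 2 (beyond the scatter) bears on this change, and it ran the opposite way, methyl arriving in place of nitro, although on a different aromatic carbon. Because a number 0.70 log units higher from compound 1 to compound 2 (beyond the scatter) was beyond the scatter, the reverse swap is expected to lower the number in this assay by a comparable amount, as a number 0.70 log units lower from compound 2 to compound 4 (beyond the scatter). For compound 4 the expected value in this assay is estimated at 2.3, with a range from 1.9 to 2.7.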

Compound 4, distribution coefficient: 2.4
For compound 4 the middle estimate is 0.10 log units below the measured one; measured number inside the range.
By their numbers in this assay, from the lowest: compounds 1 and 4 (each within the scatter of the next); then compound 2.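

The earlier step from compound 1 to compound 2 changed the group and its place together, and compound 4 now separates the two. With the place held, nitro in place of methyl on an aromatic carbon, meta to a large group, gives a number 0.60 log units lower from compound 2 to compound 4 (beyond the scatter) in this assay, so the group alone accounts for a step beyond the scatter. With the group held, 3-nitrophenyl in place of 4-nitrophenyl gives a number 0.10 log units higher from compound 1 to compound 4 (within the scatter), so in this assay the two nitro placements are not told apart, and the exchange of nitro for methyl, not the move of the nitro, carries the difference among these three compounds. No measurement here explains why the number shifts with this change.

On these data alone, whether the size of the step belongs to nitro in particular stays open, since a nitrile, an amine or a carboxylic acid at this place could sit anywhere relative to methyl. As far as these compounds go, it also stays open whether methyl, like nitro, gives the same number when moved to another aromatic carbon of the ring.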